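Isobutyl in Place of Benzyl on the Ring Nitrogen

A few compounds are considered here, and "the series" means these few. Any claim that something is new, unique, unknown or untested is made for them only; others in the source may bear on it.

Compound 1 `CC(C)n1nc(S(=O)(=O)c2cccc3ccccc23)c2cc(N3CCN(C)CC3)ccc21`: 1.8 nM
Compound 2 `O=S(=O)(c1ccc(Cl)cc1)c1n[nH]c2cc(N3CCNCC3)ccc12`: 110 nM
Compound 3 `CN1CCN(c2ccc3c(c2)c(S(=O)(=O)c2cccc4ccccc24)nn3Cc2ccccc2)CC1`: 2 nM

In an assay on HeLa cells for displacement of a labelled ligand from 5-hydroxytryptamine receptor 6 (Homo sapiens) (a lower number here means a stronger inhibitor, a higher number a weaker inhibitor), compound 3 stands second highest of the three numbers; compound 1 is nearest, and compound 2 sits far higher. Going by the values given here, the one measured step at the same position, a 1.1-fold higher number from compound 1 to compound 3 (0.05 log units; within the scatter), stayed within the scatter, so the group on that aromatic nitrogen has so far made little difference.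

Compound 4 `CC(C)Cn1nc(S(=O)(=O)c2cccc3ccccc23)c2cc(N3CCN(C)CC3)ccc21` has not yet been measured. It differs from compound 3 by isopropyl in place of phenyl on a saturated chain carbon bound to an aromatic nitrogen. Because a 1.1-fold higher number from compound 1 to compound 3 (0.05 log units; within the scatter) was within the scatter, the expected step of a 1.1-fold higher number from compound 3 to compound 4 (0.04 log units; within the scatter) is likewise small, with no clear direction. Compound 4 is therefore estimated at 2.2 nM in this assay, within a range from 0.9 nM to 5.5 nM.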

Compound 4, inhibition constant: 1.4 nM
The estimate for compound 4 lay 1.6-fold (0.20 log units) above the measured number, within the range that was stated.
By their numbers in this assay, from the lowest: compounds 4, 1 and 3 (each within the scatter of the next); then compound 2.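

Replacing the benzyl group with isobutyl removes the phenyl ring from the group on this aromatic nitrogen, yet the number barely shifts (a 1.4-fold lower number from compound 3 to compound 4 (0.15 log units; within the scatter)), and isobutyl in place of isopropyl gives the same picture (a 1.3-fold lower number from compound 1 to compound 4 (0.11 log units; within the scatter)). Benzyl, isopropyl and isobutyl are now all within the scatter of one another, so a ring in this group is not needed for a low number. No supporting measurement explains this result. Still open, from the compounds shown here alone, is how an amine, a carboxylic acid or a much longer chain would behave on this nitrogen.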